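Swapping trifluoromethyl for fluoro on the distal aromatic ring

A few compounds are considered here, and "the series" means these few. Any claim that something is new, unique, unknown or untested is made for them only; others in the source may bear on it.

Of the compounds shown here, two have been measured in an assay on HepG2 cells for agonist activity at nuclear receptor subfamily 1 group I member 3 (Homo sapiens), read by a luciferase reporter, with a stated time of 23 h; a lower number here means that less compound is needed, a higher number that more compound is needed for the effect. Compound 1 `Cc1ccc(-c2nc3sccn3c2/C=N/OCc2ccc(Cl)c(Cl)c2)cc1` gives 490 nM. Compound 2 `FC(F)(F)c1ccc(-c2nc3sccn3c2/C=N/OCc2ccc(Cl)c(Cl)c2)cc1` gives 880 nM, which is the higher of the two numbers, but the step of a 1.8-fold higher number from compound 1 to compound 2 (0.25 log units; within the scatter) lies within the scatter, so the two compounds cannot be told apart on these data. Compound 3 `Fc1ccc(-c2nc3sccn3c2/C=N/OCc2ccc(Cl)c(Cl)c2)cc1` is the next compound to be measured. It differs from compound 2 in one place: fluoro in place of trifluoromethyl on an aromatic carbon. For the measured compounds named here, the only measured step that bears on this position is the one from compound 1 to compound 2, where trifluoromethyl replaced methyl and the number barely moved. On that basis, a change of similar size is expected in this assay for compound 3, with no shift beyond the scatter. Compound 3 is therefore expected to give about 650 nM, within a range of 220 nM to 1900 nM, a step of a 1.4-fold lower number from compound 2 to compound 3 (0.13 log units; within the scatter).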

Compound 3, half-maximal effective concentration: 670 nM
Compound 3: middle estimate off by 1.0-fold (0.01 log units), on the low side; the range from low to high includes it.
By their numbers in this assay, from the lowest: compounds 1, 3 and 2 (each within the scatter of the next).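

Fluoro in place of trifluoromethyl gives a 1.3-fold lower number from compound 2 to compound 3 (0.12 log units; within the scatter) in this assay and fluoro in place of methyl gives a 1.4-fold higher number from compound 1 to compound 3 (0.14 log units; within the scatter) in the same measurement. This adds a third group at this position on the distal ring, and compound 1, compound 2 and compound 3 still cannot be told apart. Even the drop from the 4 heavy atoms of trifluoromethyl to the 1 heavy atom of fluoro leaves the number inside the scatter, and nothing available explains why these groups read alike.

From the compounds shown here alone, whether an amine, a carboxylic acid or a longer chain at this same place would shift the number beyond the scatter stays open. So does whether these three groups would still read alike if another part of the molecule were different.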